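Swapping Bromo for Nitro on a Fused Aromatic Carbon

The source may hold more compounds than are shown below. What is called first, only, known or untested is meant among the compounds shown, and "the series" means these compounds.

Going by the values given here, compound 2 `O=c1[nH]c2ccccc2cc1-c1nc2cc(Br)ccc2[nH]1` stands at the lower of the two numbers measured so far, a difference that lies within the scatter: in a functional assay on HepG2 cells (Homo sapiens) for cytotoxicity, read by MTT assay, with a stated time of 48 h (a lower number here means a stronger inhibitor, a higher number a weaker inhibitor), compound 2 gives 10800 nM. Among the compounds with values here, its nearest neighbour, compound 1 `O=c1[nH]c2ccccc2cc1-c1nc2cc(F)ccc2[nH]1`, gives 15200 nM in this assay, and the single measured step, a 1.4-fold lower number from compound 1 to compound 2 (0.15 log units; within the scatter), is small. Compound 3 `O=c1[nH]c2ccccc2cc1-c1nc2cc([N+](=O)[O-])ccc2[nH]1` carries nitro in place of bromo on an aromatic carbon. Within the data shown here, only that halogen exchange bears on this change, and it stayed within the scatter, so no step beyond the scatter is expected in this assay in either direction. Compound 3 is therefore expected to give 10000 nM, within 4000 nM to 25000 nM. This estimate means an expected step of a 1.1-fold lower number from compound 2 to compound 3 (0.03 log units; within the scatter).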

Compound 3, half-maximal inhibitory concentration: > 100000 nM
Compound 3: only a limit was reported; the forecaster's own chance of this, stated with the estimate: 5%; middle value at least 10-fold (1.00 log units) from the limit.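

The position on this aromatic carbon is not indifferent to what it carries: the exchange between the two halogens stayed within the scatter, but nitro moves the result beyond it in this assay (an at least 9.2-fold higher number from compound 2 to compound 3 (0.96 log units; beyond the scatter); an at least 6.5-fold higher number from compound 1 to compound 3 (0.81 log units; beyond the scatter)). For compound 3 this is a limit and not a number: the limit of > 100000 nM in this assay, at which 1 of the 3 values shown sits. From the compounds shown here alone, the size of the step from either halogen therefore stays open. Going by these compounds, it also remains open where an amine or a carboxylic acid on this carbon would fall, and so whether the loss belongs to nitro alone.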